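The compounds below may be only part of what the source reports. "The series", "measured", "known", "first", "only" and "open" are said of these compounds alone.

Of the compounds shown here, three sharing one core have been measured in a functional assay on ileum (strain Hartley) for agonist activity at 5-hydroxytryptamine receptor 3A (Cavia porcellus); a lower number here means a less potent compound, a higher number a more potent compound, by a factor of ten per unit of this negative logarithm. Compound 1 `CN1CCN(c2nc3cccc(Cl)c3o2)CC1` gives 5.5. Compound 2 `COc1ccc2oc(N3CCN(C)CC3)nc2c1` gives 4.78, the lowest of the three, and compound 3 `CCc1cc(Cl)cc2nc(N3CCN(C)CC3)oc12` gives 6.82, the highest. Compound 4 `CCc1ccc2oc(N3CCN(C)CC3)nc2c1` has not been measured yet. It differs from compound 2 in one place: ethyl in place of methoxy on an aromatic carbon. Going by the values given here, no measured pair shows this exact change, so its effect is not known directly. Since the two compounds without a methoxy, compound 1 with 5.5 and compound 3 with 6.82, both sit above compound 2, a rise beyond the scatter is expected in this assay, though a smaller one than compound 3 shows. Compound 4 is therefore estimated at 5.5, with a range from 4.8 to 6.2, an expected step of a number 0.72 log units higher from compound 2 to compound 4 (beyond the scatter).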

Compound 4, negative logarithm of the half-maximal effective concentration: < 4
Compound 4: only a limit was reported; the forecaster's own chance of this, stated with the estimate: 5%; middle value at least 1.50 log units from the limit.
By their numbers in this assay, from the lowest: compound 2; then compound 1; then compound 3. At a limit, below all of these: compound 4.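

In this assay, compound 4 gives < 4, which is a limit of the assay and not a number. Ethyl in place of methoxy on this aromatic carbon, with nothing else changed, therefore gives a number at least 0.78 log units lower from compound 2 to compound 4 (beyond the scatter), so removing the methoxy here does not raise potency. How far the number really falls cannot be read: the limit of < 4 in this assay, at which 1 of the 4 values shown sits.

The compounds shown leave open whether another group on this carbon, such as a hydroxyl, an amine or a longer chain, would match or exceed compound 2. They also leave open whether this change would cost as much with a chlorine elsewhere on the shared core.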